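Removing the butyl group from a cyanoaziridine urea

The source may report more compounds than this note shows. Statements on the series, on what has been measured and on what is new or still open speak of the compounds shown alone.

Measured compounds:
compound 1 `N#CC1CN1C(=O)Nc1ccc(Cl)c(Cl)c1`, 2700 nM
compound 2 `CCCCNC(=O)N1CC1C#N`, 17000 nM
compound 3 `N#CC1CN1C(=O)Nc1ccc(F)cc1`, 5900 nM

In a functional assay on RPMI-8226 cells (Homo sapiens) for inhibition (a lower number here means a stronger inhibitor, a higher number a weaker inhibitor), compound 2 gives 17000 nM, the highest number of the three. Its nearest neighbour is compound 3 with 5900 nM, and the furthest is compound 1 with 2700 nM; both gaps lie beyond the scatter, so compound 2 is the weakest inhibitor shown. Compound 4 `N#CC1CN1C(N)=O` differs from compound 2 by hydrogen in place of butyl on an amide-type nitrogen. Going by the values given here, no measured pair shows this kind of change. Since compound 2, bearing the smallest group on that nitrogen, already stands highest at 17000 nM, compound 4 is expected to be weaker still in this assay. The step from compound 2 to compound 4 is estimated at a 2.4-fold higher number from compound 2 to compound 4 (0.37 log units; beyond the scatter). For compound 4 the expected value is 40000 nM, within 12000 nM to 130000 nM.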

Compound 4, half-maximal inhibitory concentration: 432000 nM
Estimate against measurement, compound 4: 11-fold (1.03 log units) below; measured number above the stated range.
By their numbers in this assay, from the lowest: compound 1; then compound 3; then compound 2; then compound 4.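

In this assay, the group on this amide-type nitrogen proves to matter strongly: hydrogen in place of butyl gives a 25-fold higher number from compound 2 to compound 4 (1.41 log units; beyond the scatter), a large step. Going by these compounds alone, the butyl chain of compound 2, which looked like a poor substituent among the earlier compounds, thus still holds far more inhibition than the unsubstituted nitrogen of compound 4. Nothing given here accounts for the size of this step. How inhibition changes along the way from hydrogen to butyl stays open, since a methyl or propyl group on that nitrogen is not among the compounds shown. On these data alone, whether a longer chain such as octyl would lower the number further also remains unknown.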